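A few compounds are considered here, and "the series" means these few. Any claim that something is new, unique, unknown or untested is made for them only; others in the source may bear on it.

Compound 1 `CCn1c(C(=O)NCc2ccc(OC)cc2)ccc1C(CC)(CC)c1ccc(C#CC(O)(CC)CC)c(C)c1`: > 50000 nM (a limit of the assay, not a number)
Compound 2 `CCn1cc(C(CC)(CC)c2ccc(C#CC(O)(CC)CC)c(C)c2)cc1C(=O)NCC(=O)OC`: 17500 nM

Both results come from a functional assay on PC-3 cells (Homo sapiens) for antiproliferative activity, read by MTT assay, with a stated time of 72 h; a lower number here means a stronger inhibitor, a higher number a weaker inhibitor. Compound 1 gives only a limit, not a number: the limit of > 50000 nM in this assay, at which 1 of the 2 values shown sits. Among the measured compounds shown here, compound 2, at 17500 nM, therefore holds the only true number so far, and no measured step yet exists to show how much a single change can move this read-out.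

Compound 3 `CCN(CC)CCNC(=O)c1cc(C(CC)(CC)c2ccc(C#CC(O)(CC)CC)c(C)c2)cn1CC` keeps the shared core and the amide of compound 2 and alters only the end of the side chain, where (methoxycarbonyl)methyl becomes 2-(diethylamino)ethyl: (diethylamino)methyl in place of methoxycarbonyl on a saturated chain carbon bound to an amide-type nitrogen.

For the measured compounds named here, with no measured step to draw on, the size of this change remains uncertain. Going by the values given here, the only firm anchor is compound 2 at 17500 nM, so the expectation stays close to it and leans only slightly toward a stronger inhibitor. The expected change is modest, a 1.5-fold lower number from compound 2 to compound 3 (0.16 log units; within the scatter), and may not clear the usual scatter of this assay. For compound 3 the estimated value is 12000 nM, with an expected range from 4000 nM to 40000 nM.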

Compound 3, half-maximal inhibitory concentration: 5350 nM
For compound 3 the middle estimate is 2.2-fold (0.35 log units) above the measured one; the measured number falls inside the stated range.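

Among the compounds shown here, this is the first measured step in this assay. It shows that the far end of the side chain is a place where one change can move the read-out: putting (diethylamino)methyl in place of methoxycarbonyl, on a saturated chain carbon bound to an amide-type nitrogen, gives a 3.3-fold lower number from compound 2 to compound 3 (0.51 log units; beyond the scatter). The shift is real but modest, and it shows that the amide side chain can be changed without losing all measurable activity, since compound 3 still gives a true number, 5350 nM. Nothing measured here accounts for the size or direction of this step.

The compounds shown leave open whether the stronger result depends on the amine nitrogen or simply on the longer chain, a question that a plain pentyl chain with no nitrogen, or a smaller dimethylamino group at the same place, could help to answer. Also open, as far as these compounds go, is how a carboxylic acid in place of methoxycarbonyl, or a morpholine ring in place of the diethylamino group, would read in this assay.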